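The source may hold more compounds than are shown below. What is called first, only, known or untested is meant among the compounds shown, and "the series" means these compounds.

Working notes on the series.

For the measured compounds named here, compound 3 `CCCCN1CCN(CCCCn2c3c(c4ccccc42)C(=O)c2c[n+]([O-])c4ccccc4c2C3=O)CC1` gives 6900 nM in a functional assay on MCF7 cells (Homo sapiens) for cytotoxicity, read by MTT assay, with a stated time of 72 h (a higher number here means a weaker inhibitor, a lower number a stronger inhibitor), the highest of the three numbers so far. Compound 1 `CN1CCN(CCCCCn2c3c(c4ccccc42)C(=O)c2c[n+]([O-])c4ccccc4c2C3=O)CC1` gives 1260 nM and compound 2 `CN1CCN(CCCn2c3c(c4ccccc42)C(=O)c2c[n+]([O-])c4ccccc4c2C3=O)CC1` gives 220 nM in this assay. The two steps reaching compound 3 are a 5.5-fold higher number from compound 1 to compound 3 (0.74 log units; beyond the scatter) and a 31-fold higher number from compound 2 to compound 3 (1.50 log units; beyond the scatter); within the series, lengthening the chain is also seen in a 5.7-fold lower number from compound 1 to compound 2 (0.76 log units; beyond the scatter).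

Compound 4 `CN1CCN(CCCCn2c3c(c4ccccc42)C(=O)c2c[n+]([O-])c4ccccc4c2C3=O)CC1` is unmeasured. The change is hydrogen in place of propyl on a saturated chain carbon bound to an amine nitrogen in a ring. Going by the values given here, no measured step isolates the butyl-to-methyl swap on the piperazine; the nearest evidence is the pair of compounds 1 and 2, both bearing the 4-methylpiperazin-1-yl group, whose numbers bracket the chain length of compound 4. Compound 4 is therefore expected to land between them in this assay, so a large drop a 14-fold lower number from compound 3 to compound 4 (1.14 log units; beyond the scatter) is expected. Compound 4 is estimated at 500 nM, with a range from 150 nM to 1600 nM.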

Compound 4, half-maximal inhibitory concentration: 100 nM
For compound 4 the middle estimate is 5.0-fold (0.70 log units) above the measured one; the whole stated range lies above it.
By their numbers in this assay, from the lowest: compound 4; then compound 2; then compound 1; then compound 3.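

For the compounds shown here, the first reading that isolates butyl to methyl, as 4-butylpiperazin-1-yl to 4-methylpiperazin-1-yl, is a large change in this assay (a 69-fold lower number from compound 3 to compound 4 (1.84 log units; beyond the scatter)). Among the three compounds bearing 4-methylpiperazin-1-yl, the number does not move in one direction with chain length: compound 4 lies outside the other two, by a modest step on one side (a 2.2-fold lower number from compound 2 to compound 4 (0.34 log units; beyond the scatter)) and a large one on the other (a 13-fold lower number from compound 1 to compound 4 (1.10 log units; beyond the scatter)), and has the lowest number of the series. Nothing on hand bears on the cause of these steps.

From the compounds shown here alone, whether an ethyl or a 2-hydroxyethyl group in place of the butyl would give a number nearer compound 4 or compound 3 stays open. So does whether 4-butylpiperazin-1-yl costs as much on a shorter or a longer chain.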